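Cytotoxicity limits across two nitroimidazooxazine cores

A few compounds are considered here, and "the series" means these few. Any claim that something is new, unique, unknown or untested is made for them only; others in the source may bear on it.

Compound 1 `N#Cc1ccc(-c2ccc(CO[C@@H]3COc4nc([N+](=O)[O-])cn4C3)s2)cc1` and compound 2 `O=[N+]([O-])c1cn2c(n1)OC[C@@H](OCc1ccc(-c3ccc(F)cc3)s1)C2` share one core; compound 3 `Cn1c(CO[C@@H]2COc3nc([N+](=O)[O-])cn3C2)cnc1-c1ccc(C#N)cc1` and compound 4 `Cn1c(CO[C@@H]2COc3nc([N+](=O)[O-])cn3C2)cnc1-c1ccc(F)cc1` share another, and the difference between the two cores is not broken down here. In an ADME assay on Vero cells (Chlorocebus sabaeus) for cytotoxicity, with a stated time of 72 h (a higher number here means a weaker inhibitor, a lower number a stronger inhibitor), compound 1 reaches only the assay limit, > 128000 nM. In this assay compound 2 likewise reaches only the limit, > 128000 nM. For compound 3 this assay also returns only the limit, > 128000 nM. The change from compound 1 to compound 2, (fluoro in place of cyano on an aromatic carbon), gives a step that the two limits leave unreadable from compound 1 to compound 2, unreadable because of the limit of > 128000 nM in this assay, at which 3 of the 3 values shown sit. The change from compound 3 to compound 4, (fluoro in place of cyano on an aromatic carbon), is the same change at the same place. Compound 4 is therefore expected to stay at the limit, with an estimated step that the limit leaves unreadable from compound 3 to compound 4. The estimate for compound 4 is 200000 nM, expected between 128000 nM and 600000 nM.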

Compound 4, half-maximal inhibitory concentration: > 128000 nM
Compound 4 ended at the assay's limit (the forecaster's own chance of this, stated with the estimate: 85%); the middle value does not contradict the limit.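

In this assay no step can be read for compound 3 and compound 4, because both reach only a limit: the limit of > 128000 nM in this assay, at which 4 of the 4 values shown sit.

The compounds shown leave open whether fluoro in place of cyano changes cytotoxicity on either core, and how the two cores compare.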